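A few compounds are considered here, and "the series" means these few. Any claim that something is new, unique, unknown or untested is made for them only; others in the source may bear on it.

Compound 1 `CC(C)(C)[C@@H](O)C(=O)N1[C@@H]2C[C@@H]2C[C@H]1C(=O)NCc1cc(Cl)ccc1-n1cnnn1` gives 1100 nM in a functional assay on a cell-free system (plasma, Homo sapiens), with a stated time of 3 min; a higher number here means a weaker inhibitor, a lower number a stronger inhibitor. Compound 2 `O=C(NCc1cc(Cl)ccc1-n1cnnn1)[C@@H]1C[C@H]2C[C@H]2N1C(=O)[C@H](O)c1cccc(F)c1` gives 1100 nM, and compound 3 `CCCC[C@@H](O)C(=O)N1[C@@H]2C[C@@H]2C[C@H]1C(=O)NCc1cc(Cl)ccc1-n1cnnn1` gives 870 nM. Compound 1 stands level with compound 2 at the digits shown, the two together the highest of the three numbers; nearest is compound 2 with no change at the digits printed from compound 1 to compound 2 (within the scatter), furthest compound 3 with a 1.3-fold lower number from compound 1 to compound 3 (0.10 log units; within the scatter), and a 1.3-fold lower number from compound 2 to compound 3 (0.10 log units; within the scatter) is of the same size. Compound 4 `CC(C)(C)[C@@H](O)C(=O)N1[C@H](C(=O)NCc2cc(Cl)ccc2-n2cnnn2)C[C@@H]2C[C@@H]21` is not yet measured. the two compounds have the same atoms and bonds and differ only in configuration as drawn: 2 of 4 stereo elements differ; a stereocentre at a saturated ring carbon is drawn R in compound 1 and S in compound 4; a stereocentre at a saturated ring carbon is drawn R in compound 1 and S in compound 4 None of the three measured steps touches configuration; each exchanges the group on the saturated chain carbon bound to a carbonyl carbon and an oxygen on a saturated carbon, and each lies within the scatter, so they give no guide to the size or direction of this step in this assay. Compound 4 is therefore estimated at 3500 nM, within 700 nM to 20000 nM. The expected step from compound 1 is a 3.2-fold higher number from compound 1 to compound 4 (0.50 log units; beyond the scatter), weighted toward a weaker inhibitor but with wide uncertainty.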

Compound 4, half-maximal inhibitory concentration: 1500 nM
For compound 4 the middle estimate is 2.3-fold (0.37 log units) above the measured one; the measured number falls inside the stated range.
By their numbers in this assay, from the lowest: compounds 3, 1, 2 and 4 (each within the scatter of the next).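

In this assay, the change of two ring stereocentres gives a 1.4-fold higher number from compound 1 to compound 4 (0.13 log units; within the scatter), so with tert-butyl on the chain carbon, the configuration drawn at these two ring carbons shows no effect beyond the scatter. Going by these compounds alone, the earlier steps changed only the chain substituent, and this is the first reading for the core's configuration. No atoms or bonds change in this step: the fact that compounds 1 and 4 differ only in the configuration as drawn

On these data alone, the separate contribution of each stereocentre remains open, as does whether butyl or 3-fluorophenyl would tolerate the same inversion. As far as these compounds go, the reading with a carboxylic acid or an amine in place of tert-butyl also remains open.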